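The compounds below may be only part of what the source reports. "The series", "measured", "known", "first", "only" and "open" are said of these compounds alone.

Compound 1 `CC(C)COc1ccc2oc(/C=C/[S+](C)[O-])cc(=O)c2c1` is the anchor of this small series. In a functional assay on A549 cells (Homo sapiens) for cytotoxicity, with a stated time of 48 h (on this read-out lower numbers stand for stronger inhibition and higher numbers for weaker inhibition), compound 1 gives 1100 nM, the lowest of the three numbers recorded. Compound 3 `C[S+]([O-])/C=C/c1oc2ccccc2c(=O)c1Cc1ccccc1` gives 1300 nM in this assay, a difference from compound 1 that lies within the scatter of repeated measurements. Compound 2 `CC(C)CC(=O)Oc1ccc2oc(/C=C/[S+](C)[O-])cc(=O)c2c1` gives 2300 nM in this assay, and the step of a 2.1-fold higher number from compound 1 to compound 2 (0.32 log units; beyond the scatter) shows that swapping isobutylcarbonyl for isobutyl on the oxygen of the shared core weakens the effect modestly.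

Compound 4 `C[S+]([O-])/C=C/c1cc(=O)c2cc(Br)ccc2o1` has not yet been tested. It differs from compound 1 by bromo in place of isobutoxy on an aromatic carbon. Within the data shown here, the only measured step at this position, from compound 1 to compound 2, kept the oxygen and altered the group hanging from it; the move to bromo removes that oxygen-linked group entirely, so no measured step mirrors it directly. That single step was modest, which suggests that changes here shift the number by a modest amount rather than transforming it.

Compound 4 is therefore expected to give 1800 nM in this assay, with a plausible range from 700 nM to 4500 nM. The estimate corresponds to an expected step of a 1.6-fold higher number from compound 1 to compound 4 (0.21 log units; within the scatter), a slight weakening whose direction is uncertain.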

Compound 4, half-maximal inhibitory concentration: 1100 nM
Compound 4: the middle estimate sits 1.6-fold (0.21 log units) above what was measured, and the stated range covers the measured number.
By their numbers in this assay, from the lowest: compounds 1, 4, 3 and 2 (each within the scatter of the next, the first and the last beyond it).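

Replacing isobutoxy, a chain of five heavy atoms, with a single bromo atom on this aromatic carbon gives no change at the digits printed from compound 1 to compound 4 (within the scatter) in this assay, so the oxygen-linked chain of compound 1 is not needed to keep this level of cytotoxicity. Moving to bromo from the (isobutylcarbonyl)oxy group gives a 2.1-fold lower number from compound 2 to compound 4 (0.32 log units; beyond the scatter), which leaves the group on compound 2 as the only one of the three at this position whose number stands apart from the others. Nothing available here accounts for why these groups compare as they do.

Going by these compounds, whether an amine, a carboxylic acid or a longer chain on this aromatic carbon would hold the number near that of compound 1, or move it in either direction, remains open. On these data alone, compound 3 differs from the other compounds in more than one place, so it cannot show what the shared core does with no group at all on this carbon, and that comparison also stays open.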